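A few compounds are considered here, and "the series" means these few. Any claim that something is new, unique, unknown or untested is made for them only; others in the source may bear on it.

Measured compounds:
- Compound 1, `COc1ccccc1-c1ccn(CCC(C)C)c(=O)c1C#N`: in a functional assay on CHO cells for positive allosteric modulation of metabotropic glutamate receptor 2 (Homo sapiens), read by scintillation counting and GTPgammaS binding, with a stated time of 30 min (a lower number here means that less compound is needed, a higher number that more compound is needed for the effect), compound 1 gives > 10000 nM; this is a limit of the assay, not a number.
- Compound 2, `CC(C)CCn1ccc(-c2ccc(Oc3ccccc3)cc2)c(C#N)c1=O`: in this assay compound 2 gives 42 nM.

Compound 2 holds the only number shown in this assay; the other value shown, that of compound 1, sits at the limit of > 10000 nM in this assay, at which 1 of the 2 values shown sits. Compound 2 and compound 1 share the core, and compound 2 carries a phenoxy on the aromatic ring in place of the methoxy of compound 1; nothing beyond their two values can be said of that pair.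

Compound 3, `Cc1ncccc1Oc1ccc(-c2ccn(CCC(C)C)c(=O)c2C#N)cc1`, is not yet measured in this assay. Its difference from compound 2 is 2-methylpyridin-3-yl in place of phenyl on an oxygen on an aromatic ring, in words 2-methylpyridin-3-yl in place of phenyl on an oxygen on an aromatic ring. Among the compounds with values here, no measured step of this kind is available, so the expected step of a 1.9-fold higher number from compound 2 to compound 3 (0.28 log units; within the scatter) is set small, toward slightly more compound needed, and within or just beyond the scatter. Compound 3 is estimated at 80 nM in this assay, with a range from 25 nM to 300 nM.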

Compound 3, half-maximal effective concentration: 275 nM
Compound 3: middle estimate off by 3.4-fold (0.54 log units), on the low side; low and high end bracket the measured number.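

With 2-methylpyridin-3-yl in place of phenyl on an oxygen on an aromatic ring, this assay shows a 6.5-fold higher number from compound 2 to compound 3 (0.82 log units; beyond the scatter), so this position is not indifferent to the change, although compound 3 still gives a measured value. The change brings in a ring nitrogen and a methyl at once, so the step cannot be divided between the two. No measurement shown gives a reason for the step.

Still open, going by these compounds, is whether the ring nitrogen or the methyl carries the step, which a plain pyridin-3-yl or a 2-methylphenyl on the same oxygen would separate. Also open is how a ring bearing an amine or a carboxylic acid would read at this position, as the compounds shown offer only one replacement for the phenyl of the phenoxy group.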